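Amide substituent change on the shared core, acid to alcohol

The compounds below may be only part of what the source reports. "The series", "measured", "known", "first", "only" and "open" are said of these compounds alone.

Compound 1 `CCOC(=O)C(CC(=O)OC)NC(=O)c1ccc(C(CC)(CC)c2ccc(OCCC(O)(CC)CC)c(C)c2)n1CC` gives 21 nM in an assay on cells for agonist activity at vitamin D3 receptor (Homo sapiens), with a stated time of 96 h; a lower number here means that less compound is needed, a higher number that more compound is needed for the effect. Compound 2 `CCn1c(C(=O)NC(C)C(=O)O)ccc1C(CC)(CC)c1ccc(OCCC(O)(CC)CC)c(C)c1` gives 66 nM in this assay, the highest of the two numbers, with the step of a 3.1-fold higher number from compound 1 to compound 2 (0.50 log units; beyond the scatter) separating them. Compound 3 `CCC(C)C(CO)NC(=O)c1ccc(C(CC)(CC)c2ccc(OCCC(O)(CC)CC)c(C)c2)n1CC` differs from compound 2 by 1-(hydroxymethyl)-2-methylbutyl in place of 1-carboxyethyl on an amide-type nitrogen. Among the compounds with values here, only the step from compound 1 to compound 2 bears on this place, and it moved the number modestly when the amide-type nitrogen substituent was changed. A step of similar or smaller size toward a lower number is expected, a 1.9-fold lower number from compound 2 to compound 3 (0.28 log units; within the scatter). Compound 3 is therefore estimated at 35 nM, within 10 nM to 120 nM.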

Compound 3, half-maximal effective concentration: 450 nM
Estimate against measurement, compound 3: 13-fold (1.11 log units) below; measured number outside the range, above it.
By their numbers in this assay, from the lowest: compound 1; then compound 2; then compound 3.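

In this assay, within the data shown here, the substituent on the amide-type nitrogen proves able to move the number further than the earlier pair showed: 1-(hydroxymethyl)-2-methylbutyl in place of 1-carboxyethyl gives a 6.8-fold higher number from compound 2 to compound 3 (0.83 log units; beyond the scatter) and, measured against the group of compound 1, a 21-fold higher number from compound 1 to compound 3 (1.33 log units; beyond the scatter), the one large step so far. The counts of hydrogen-bond donors and acceptors are the same in the leaving and entering groups, so those counts do not separate compound 2 from compound 3. Nothing available accounts for this change.

From the compounds shown here alone, whether the step follows the loss of the carboxylic acid or the larger carbon chain remains open. A 2-hydroxy-1-methylethyl group on this nitrogen would separate the two.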